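The compounds below may be only part of what the source reports. "The series", "measured", "known", "first", "only" and "open" are said of these compounds alone.

Measured compounds:
compound 1, `Cc1nc(SCC(=O)Nc2nc(-c3ccc(Cl)cc3)cs2)n(Nc2ccccc2)c1C`: 17000 nM
compound 2, `Cc1ccc(Nn2c(SCC(=O)Nc3nc(-c4ccccc4)cs3)nc(C)c2C)cc1`: 9290 nM

In a functional assay on UACC-257 cells (Homo sapiens) for antiproliferative activity, read by sulforhodamine B assay, with a stated time of 48 h (on this read-out higher numbers stand for weaker inhibition of growth and lower numbers for stronger inhibition of growth), compound 1 gives 17000 nM, the higher of the two numbers, while compound 2 gives 9290 nM; the gap between them lies within the scatter, so neither stands apart. Compound 3, `COc1ccc(Nn2c(SCC(=O)Nc3nc(-c4ccc(Cl)cc4)cs3)nc(C)c2C)cc1`, differs from compound 1 by methoxy in place of hydrogen on an aromatic carbon. Within the data shown here, no pair of measured compounds isolates such a change, so compound 3 is expected to stay near compound 1, with a step of a 1.4-fold lower number from compound 1 to compound 3 (0.15 log units; within the scatter) not clearly beyond the scatter. Compound 3 is estimated at 12000 nM, between 4000 nM and 35000 nM.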

Compound 3, concentration for total growth inhibition: 41100 nM
Compound 3: middle estimate off by 3.4-fold (0.53 log units), on the low side; the measured number lies above the stated range.
By their numbers in this assay, from the lowest: compounds 2 and 1 (each within the scatter of the next); then compound 3.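

In this assay, methoxy in place of hydrogen on this aromatic carbon, para to a large group, gives a 2.4-fold higher number from compound 1 to compound 3 (0.38 log units; beyond the scatter), a modest step and the first here that lies beyond the scatter. This carbon of the anilino group is therefore not indifferent to change: phenyl to 4-methoxyphenyl weakens growth inhibition in this pair. Nothing at hand bears on the reason for this step. Going by these compounds, what a hydroxyl or an amine on the same carbon would do stays open, as does whether methoxy gives a similar step on a compound without the chlorine.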